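The compounds below may be only part of what the source reports. "The series", "measured", "known", "first", "only" and "open" are said of these compounds alone.

Measured so far in an assay on HEK293 cells for displacement of a labelled ligand from Sigma non-opioid intracellular receptor 1 (Homo sapiens), read by scintillation counting, with a stated time of 120 min; a higher number here means a weaker inhibitor, a lower number a stronger inhibitor:
compound 1 `Cc1cccc(-c2ncnc3c2cnn3CCN2CCCCC2)c1`: 82 nM
compound 2 `COc1ccc(-c2ncnc3c2cnn3CCN2CCCCC2)cc1`: 531 nM
compound 3 `COc1ccc(-c2ncnc3c2cnn3CCN2CCCCC2)cn1`: 38300 nM

Compound 1 gives the lowest number of the three; compound 2 is nearest, with a 6.5-fold higher number from compound 1 to compound 2 (0.81 log units; beyond the scatter), and compound 3 furthest, with a 470-fold higher number from compound 1 to compound 3 (2.67 log units; beyond the scatter). Compound 4 `Cn1cc(-c2ncnc3c2cnn3CCN2CCCCC2)cn1` differs from compound 1 by 1-methyl-1H-pyrazol-4-yl in place of 3-methylphenyl on an aromatic carbon. Within the data shown here, two measured steps bear on this: a 6.5-fold higher number from compound 1 to compound 2 (0.81 log units; beyond the scatter) went with a change of substituent on an all-carbon six-membered ring, while a 72-fold higher number from compound 2 to compound 3 (1.86 log units; beyond the scatter) went with a ring nitrogen entering that aryl group. The new group, a five-membered ring with two hetero atoms, goes further than either measured change, so a large rise in this assay is expected. For compound 4 the expected value is 6000 nM, with a range from 900 nM to 40000 nM. This estimate means a step of a 73-fold higher number from compound 1 to compound 4 (1.86 log units; beyond the scatter).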

Compound 4, inhibition constant: 9460 nM
Estimate against measurement, compound 4: 1.6-fold (0.20 log units) below, within the range that was stated.
By their numbers in this assay, from the lowest: compound 1; then compound 2; then compound 4; then compound 3.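

In this assay replacing 3-methylphenyl with 1-methyl-1H-pyrazol-4-yl gives a 120-fold higher number from compound 1 to compound 4 (2.06 log units; beyond the scatter) and shows that this position also loses much with a five-membered aromatic ring, not only with six-membered aryl groups. The pyrazole falls between the two methoxy compounds, with a 4.0-fold lower number from compound 3 to compound 4 (0.61 log units; beyond the scatter) and an 18-fold higher number from compound 2 to compound 4 (1.25 log units; beyond the scatter) as the two steps, so ring nitrogen alone does not fix the size of the loss. No measured evidence on these steps is available to explain them.

Still open, as far as these compounds go, is whether a 3-chlorophenyl group would stay close to compound 1. From the compounds shown here alone, whether a morpholine ring or an unmethylated pyrazole is tolerated here is also open.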